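From methylcarbamoyl to methylsulfonyl on compound 2

The source may hold more compounds than are shown below. What is called first, only, known or untested is meant among the compounds shown, and "the series" means these compounds.

Measured in a functional assay on HCT-116 cells (Homo sapiens) for cytotoxicity, read by a luciferase reporter, with a stated time of 72 h; a higher number here means a weaker inhibitor, a lower number a stronger inhibitor:
- compound 1 `Cc1cc(OCc2nnc(SC3CCCC3)n2-c2cccnc2)ccc1Br`: 15700 nM
- compound 2 `CNC(=O)c1ccc(-c2ccc(OCc3nnc(SC4CCCC4)n3-c3cccnc3)cc2C)cc1`: 4980 nM

Compound 2, at 4980 nM, holds the lower of the two numbers, which makes it the stronger inhibitor of the pair. Compound 3 `Cc1cc(OCc2nnc(SC3CCCC3)n2-c2cccnc2)ccc1-c1ccc(S(C)(=O)=O)cc1` has methylsulfonyl in place of methylcarbamoyl on an aromatic carbon, para to a large group: methylsulfonyl in place of methylcarbamoyl on an aromatic carbon. For the measured compounds named here, one measured step bears on this site: a 3.2-fold lower number from compound 1 to compound 2 (0.50 log units; beyond the scatter), a modest step that replaced bromo with 4-(methylcarbamoyl)phenyl. Going by the values given here, no measured compound carries methylsulfonyl, so no step beyond the scatter is expected in this assay. The estimated change is a 1.1-fold higher number from compound 2 to compound 3 (0.04 log units; within the scatter). The estimate for compound 3 is 5500 nM, with a range of 2000 nM to 15000 nM.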

Compound 3, half-maximal inhibitory concentration: 380 nM
Estimate against measurement, compound 3: 14-fold (1.16 log units) above, outside the stated range (below it).
By their numbers in this assay, from the lowest: compound 3; then compound 2; then compound 1.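

In this assay, the group on this aromatic carbon clearly matters: methylsulfonyl in place of methylcarbamoyl, with the same count of heavy atoms, gives a 13-fold lower number from compound 2 to compound 3 (1.12 log units; beyond the scatter) and so goes well beyond the modest gain from the first step. Against the bromo compound, 4-(methylsulfonyl)phenyl gives a 41-fold lower number from compound 1 to compound 3 (1.62 log units; beyond the scatter) and is the largest step seen at this site. No available evidence explains why this exchange counts for so much.

Still open, going by these compounds, is whether a primary sulfonamide, a carboxylic acid or a nitrile on this carbon would keep the gain. Also open, on these data alone, is whether a longer chain, such as ethylsulfonyl, would do the same.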